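The source may hold more compounds than are shown below. What is called first, only, known or untested is meant among the compounds shown, and "the series" means these compounds.

Measured compounds:
Compound 1, `O=C(CSc1snnc1-c1ccc(Br)cc1Br)Nc1ccccc1F`, in an ADME assay on MT4 cells (Homo sapiens) for cytotoxicity, read by MTT assay, with a stated time of 5 days (on this read-out higher numbers stand for lower toxicity in this test and lower numbers for higher toxicity in this test), gives >= 27800 nM, which is a limit of the test rather than a number.
Compound 2, `Cc1cccc(C)c1NC(=O)CSc1snnc1-c1ccc(Br)cc1Br`, gives >= 198000 nM, also a limit.
Compound 3, `O=C(CSc1snnc1-c1ccc(Br)cc1Br)Nc1ccccn1`, gives 42400 nM.

Compound 3 therefore stands as the only one of the three with a true number; the other two values are limits, so the steps a step that the two limits leave unreadable from compound 1 to compound 2 and a step that the limit leaves unreadable from compound 1 to compound 3 cannot be read. Among the compounds with values here, the single readable step is an at least 4.6-fold lower number from compound 2 to compound 3 (0.66 log units; beyond the scatter), and its size rests partly on a limit, (the limit of >= 198000 nM in this assay, at which 1 of the 3 values shown sits).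

Compound 4, `O=C(CSc1snnc1-c1ccc(Br)cc1Br)Nc1nccs1`, differs from compound 3 by 1,3-thiazol-2-yl in place of pyridin-2-yl on an amide-type nitrogen. Within the data shown here, no measured step exchanges one small aromatic ring for another of this kind; the readable step from compound 2 to compound 3 concerns a different ring on the same amide-type nitrogen and gives no direct guide. With nothing bearing directly on this change, a step within the scatter is expected, a 1.1-fold lower number from compound 3 to compound 4 (0.03 log units; within the scatter). Compound 4 is thus estimated at 40000 nM, expected to fall between 15000 nM and 120000 nM.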

Compound 4, half-maximal cytotoxic concentration: 87800 nM
The estimate for compound 4 lay 2.2-fold (0.34 log units) below the measured number; the range from low to high includes it.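

In this assay, exchanging one small aromatic ring for another on the amide-type nitrogen is not a neutral change: 1,3-thiazol-2-yl in place of pyridin-2-yl gives a 2.1-fold higher number from compound 3 to compound 4 (0.32 log units; beyond the scatter), which makes compound 4 the less toxic of this pair in this test. Both of these rings now stand on the lower side of 2,6-dimethylphenyl, and the thiazole gives an at least 2.2-fold lower number from compound 2 to compound 4 (0.35 log units; beyond the scatter). Compound 2 gives only a limit, so the size of that step rests partly on it: the limit of >= 198000 nM in this assay, at which 1 of the 4 values shown sits.

From the compounds shown here alone, the step from compound 1 cannot be read, as compound 1 also gives only a limit: the limit of >= 27800 nM in this assay, at which 1 of the 4 values shown sits. Still open is how an unsubstituted phenyl, or a pyridin-2-yl or 1,3-thiazol-2-yl carrying a methyl, an amine or a carboxylic acid, would read on this same nitrogen.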